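A pyrazine in place of the oxazole of compound 1

The source may report more compounds than this note shows. Statements on the series, on what has been measured and on what is new or still open speak of the compounds shown alone.

Compound 1 `Cc1nc(-c2ccccc2NCC2=NCCN2)co1` was tested in a functional assay for activation of Alpha-1B adrenergic receptor (Homo sapiens), read by calcium flux; on this read-out higher numbers stand for an effect only at larger amounts of compound and lower numbers for an effect already at smaller amounts. For compound 1 only a limit is known, < 5020 nM. Compound 3 `Cc1noc(-c2ccccc2NCC2=NCCN2)n1` also shows only a limit, < 5020 nM. Compound 2 `Cc1cc(-c2ccccc2NCC2=NCCN2)on1` gives 95.5 nM. The steps a step that the limit leaves unreadable from compound 1 to compound 2, a step that the two limits leave unreadable from compound 1 to compound 3 and a step that the limit leaves unreadable from compound 2 to compound 3 cannot be sized because of the limit of < 5020 nM in this assay, at which 2 of the 3 values shown sit. Compound 4 `c1ccc(-c2cnccn2)c(NCC2=NCCN2)c1` differs from compound 1 by pyrazin-2-yl in place of 2-methyl-1,3-oxazol-4-yl on an aromatic carbon. Among the compounds with values here, none of the measured steps involves this change, and the one step that starts from compound 1 with a readable endpoint gives no size, so no direction can be read from the data. Compound 4 is therefore expected to give about 800 nM, within 80 nM to 8000 nM. The step that the limit leaves unreadable from compound 1 to compound 4 is thus an estimate with little support, and the limit on compound 1 leaves its size open.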

Compound 4, half-maximal effective concentration: 339 nM
For compound 4 the middle estimate is 2.4-fold (0.37 log units) above the measured one, and the stated range covers the measured number.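

In this assay, pyrazin-2-yl, a six-membered aromatic ring, gives a readable number on this aromatic carbon, so a readable number here does not depend on a five-membered ring. Replacing 3-methyl-1,2-oxazol-5-yl with pyrazin-2-yl gives a 3.5-fold higher number from compound 2 to compound 4 (0.55 log units; beyond the scatter), a modest step, so compound 2 acts at smaller amounts. The steps to compound 4 from compound 1 and compound 3 cannot be read, since both of those compounds carry only a limit: the limit of < 5020 nM in this assay, at which 2 of the 4 values shown sit.

Still open, from the compounds shown here alone, is how a plain phenyl ring, an amine or a carboxylic acid would read at this place. Also open, going by these compounds, is whether a methyl group on the pyrazin-2-yl ring would shift the number.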